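A few compounds are considered here, and "the series" means these few. Any claim that something is new, unique, unknown or untested is made for them only; others in the source may bear on it.

Measured in a functional assay on MCF7 cells (Homo sapiens) for inhibition, read by sulforhodamine B assay, with a stated time of 48 h; on this read-out lower numbers stand for stronger inhibition of growth and higher numbers for weaker inhibition of growth:

- compound 1 `N#CCC1=NN=C(c2ccc(Br)cc2)C(CC(=O)c2ccc(Br)cc2)O1`: 30400 nM
- compound 2 `N#CCC(=O)N/N=C(/CBr)c1ccc([N+](=O)[O-])cc1`: 18400 nM
- compound 3 `N#CCC1=C(C#N)CC(c2ccc(Br)cc2)=C(CC(=O)c2ccc(Br)cc2)O1`: 12000 nM

Compound 3 and compound 2 lie within the usual scatter of each other, while compound 1 gives a higher number than compound 3, beyond the scatter. Compound 4 `N#CCC1=C(C#N)CC(c2ccc([N+](=O)[O-])cc2)=C(CC(=O)c2ccc(Br)cc2)O1` is compound 3 with nitro in place of bromo on an aromatic carbon, para to a large group: nitro in place of bromo on an aromatic carbon. Going by the values given here, no measured pair differs in one place only, so no direct step is available. Compound 2, which carries 4-nitrophenyl, gives 18400 nM, so in this assay no step beyond the scatter is expected. The expected change is a 1.1-fold lower number from compound 3 to compound 4 (0.04 log units; within the scatter). For compound 4 the estimated value is 11000 nM, with an expected range of 3500 nM to 30000 nM.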

Compound 4, concentration for 50% growth inhibition: 4900 nM
Compound 4: middle estimate off by 2.2-fold (0.35 log units), on the high side; the measured number falls inside the stated range.
By their numbers in this assay, from the lowest: compound 4; then compounds 3, 2 and 1 (each within the scatter of the next, the first and the last beyond it).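

In this assay, going by these compounds alone, putting nitro in place of bromo, para to a large group, gives a 2.4-fold lower number from compound 3 to compound 4 (0.39 log units; beyond the scatter) and is the first direct reading of a single change in this set. It shows that the number responds to what sits at this position on the aromatic ring. No measurement here accounts for the step.

On these data alone, whether an amine or a carboxylic acid at this position would move the number as nitro does remains open. So does the effect of changing the 4-bromophenyl that compound 3 and compound 4 share.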